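This account rests on a few compounds, and the source may have more. Where it says the series, first, only, none or still open, it means among the compounds named here.

Compound 3 `CN(Cc1cccnc1)C(=S)SCc1ccc(C(=O)Nc2ccccc2N)cc1` is the starting point here. In a functional assay on A-375 cells (Homo sapiens) for antiproliferative activity, read by CCK-8 assay, with a stated time of 72 h, tested at 8 uM (a higher number here means a stronger effect of the compound at the concentration tested, a lower number a weaker effect), compound 3 gives 83.8%, which on the numbers shown stands second highest of three, though every gap among them is within the scatter. Compound 1 `Nc1ccccc1NC(=O)c1ccc(CSC(=S)N2CCc3cc(Cl)ccc32)cc1` gives 82.3% in this assay, and compound 2 `CN1CCN(C(=S)SCc2ccc(C(=O)Nc3ccccc3N)cc2)CC1` gives 91.6%. Compound 4 `Nc1ccccc1NC(=O)c1ccc(CSC(=S)N2CCCC2)cc1` is not yet measured and differs from compound 3 in one place: pyrrolidin-1-yl in place of methyl((pyridin-3-yl)methyl)amino on a thiocarbonyl carbon. Two earlier swaps of the group on the thiocarbonyl carbon bear on this: a number 1.5 percentage points higher from compound 1 to compound 3 (within the scatter) and a number 7.8 percentage points lower from compound 2 to compound 3 (within the scatter). Three different groups at that spot gave numbers within the scatter of one another. The step of a number 0.2 percentage points higher from compound 3 to compound 4 (within the scatter) is therefore expected to stay within the scatter. Compound 4 is estimated to give 84%, with a range from 70% to 95%.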

Compound 4, a percentage reported as inhibition, at one concentration (the size of the read-out at that concentration, not a potency): 89.5%
For compound 4 the middle estimate is 5.5 percentage points below the measured one, within the range that was stated.
By their numbers in this assay, from the lowest: compounds 1, 3, 4 and 2 (each within the scatter of the next).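

Pyrrolidin-1-yl on the thiocarbonyl carbon gives a fourth group whose number in this assay lies close to the others: a number 5.7 percentage points higher from compound 3 to compound 4 (within the scatter) and a number 2.1 percentage points lower from compound 2 to compound 4 (within the scatter) and a number 7.2 percentage points higher from compound 1 to compound 4 (within the scatter) all say so. Without the pyridine ring of compound 3 or the second ring nitrogen of compound 2, the read-out therefore stays within the scatter, so neither feature is needed for this effect at this concentration. No measurement shown here explains this.

Going by these compounds, whether a longer alkyl chain or a carboxylic acid at this position would keep the number within the scatter remains open. So does whether any of these compounds would show a stronger or weaker effect at another concentration, which one concentration cannot show.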